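Replacing a Hydroxyazetidine Arm with a Glycolamide

The source may report more compounds than this note shows. Statements on the series, on what has been measured and on what is new or still open speak of the compounds shown alone.

Three measured compounds share a core in which a sulfonyl group links two ring systems, and a short side arm sits on a saturated ring carbon. In an assay on isolated protein for displacement of a labelled ligand from 5-hydroxytryptamine receptor 6 (Homo sapiens) (a higher number here means a weaker inhibitor, a lower number a stronger inhibitor), compound 1 `N#Cc1cccc(S(=O)(=O)c2ccc3c(c2)CCC[C@H]3C=N)c1` gives 0.501 nM. Compound 2 `NC[C@@H]1CCCc2cc(S(=O)(=O)c3c[nH]c4ccccc34)ccc21` gives 0.0501 nM. Compound 3 `O=S(=O)(c1cccc(F)c1)c1ccc2c(c1)CCC[C@H]2CN1CC(O)C1` gives 0.1 nM, the second highest of the three numbers; its gap to compound 2 lies within the scatter, while compound 1 sits further away, beyond the scatter.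

Compound 4 `O=C(CO)NC[C@@H]1CCCc2cc(S(=O)(=O)c3cccc(F)c3)ccc21` has not yet been measured. It differs from compound 3 in one place: ((hydroxymethyl)carbonyl)amino in place of 3-hydroxyazetidin-1-yl on a saturated chain carbon bound to a saturated ring carbon. Within the data shown here, no measured pair shows this particular exchange, so no step for it is known.

The expectation for compound 4 rests on the two hydroxy-bearing side arms being similar in size and count of heavy atoms. A small weakening is expected, estimated as a 3.0-fold higher number from compound 3 to compound 4 (0.48 log units; beyond the scatter), which may still fall within the scatter. Compound 4 is therefore expected to give about 0.3 nM, with a range from 0.08 nM to 1.5 nM.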

Compound 4, inhibition constant: 0.1 nM
Compound 4: the middle estimate sits 3.0-fold (0.48 log units) above what was measured; the measured number falls inside the stated range.
By their numbers in this assay, from the lowest: compounds 2, 3 and 4 (each within the scatter of the next); then compound 1.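

In this assay, putting ((hydroxymethyl)carbonyl)amino in place of 3-hydroxyazetidin-1-yl gives no change at the digits printed from compound 3 to compound 4 (within the scatter) on a saturated chain carbon bound to a saturated ring carbon. Among these compounds, this is the first exchange that can be read in one place, and it shows that, for this pair, the four-membered ring can give way to an open arm with a carbonyl and an amide hydrogen without any change beyond the scatter. No measurement here offers a reason why the two arms match.

As far as these compounds go, it stays open what acetylamino, which has no hydroxy group, or a longer chain such as 3-hydroxypropanoylamino would give at this place. From the compounds shown here alone, whether the same exchange would also leave the number unchanged on the core of compound 2 is equally open.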